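Compound 1 to compound 4: an imidazole exchange

The compounds below may be only part of what the source reports. "The series", "measured", "known", "first", "only" and "open" are said of these compounds alone.

In a physicochemical assay for solubility, read by LC-MS, in phosphate buffer, with a stated time of 24 h, at pH 7.4 (a higher number here means a more soluble compound, a lower number a less soluble compound), compound 1 `Cc1nccn1-c1cnc(NCc2c(F)ccc3c2CCO3)c2cn[nH]c(=O)c12` gives 7000 nM as the lowest of three numbers, and the gaps to the other two lie beyond the scatter. Compound 2 `C[C@@H]1CC(=O)N(c2cnc(NCc3c(F)ccc4c3CCO4)n3cnnc23)C1` gives 130000 nM and compound 3 `COCCC(=O)Nc1cnc(NCc2c(F)ccc3c2CCO3)n2cnnc12` gives 980000 nM on a different core. Compound 4 `Cc1ncc(-c2cnc(NCc3c(F)ccc4c3CCO4)c3cn[nH]c(=O)c23)n1C` has 1,2-dimethyl-1H-imidazol-5-yl in place of 2-methyl-1H-imidazol-1-yl on an aromatic carbon. Among the compounds with values here, the only measured step, a 7.5-fold higher number from compound 2 to compound 3 (0.88 log units; beyond the scatter) on that other core, exchanges different groups, so it bears only loosely and sets no direction here. No step beyond the scatter is therefore expected in this assay and the estimated 1.1-fold higher number from compound 1 to compound 4 (0.06 log units; within the scatter) stays small. For compound 4 the estimated value is 8000 nM within an expected range from 2000 nM to 30000 nM for this measurement.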

Compound 4, solubility: 15000 nM
Compound 4: the middle estimate sits 1.9-fold (0.27 log units) below what was measured; measured number inside the range.
By their numbers in this assay, from the lowest: compound 1; then compound 4; then compound 2; then compound 3.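

In this assay the exchange on the shared core gives a 2.1-fold higher number from compound 1 to compound 4 (0.33 log units; beyond the scatter) and is the first step shown at this position, on an aromatic carbon para to a large group. The number therefore moves, modestly but beyond the scatter, even though the two groups are both five-membered aromatic rings with 2 hetero atoms. Nothing measured here accounts for the step. The compounds shown leave open how a morpholine, an amine or a carboxylic acid would read at this position, and whether an imidazole is needed there at all.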